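The source may report more compounds than this note shows. Statements on the series, on what has been measured and on what is new or still open speak of the compounds shown alone.

Three compounds have been measured in a functional assay on L1210 cells (Mus musculus) for inhibition, with a stated time of 48 h; a lower number here means a stronger inhibitor, a higher number a weaker inhibitor:

Compound 1, `COC(=O)C[C@H](NC(=O)OCc1ccccc1)C(=O)N(Cc1ccccc1)C1(C(=O)NCc2ccccc2)CCN(Cc2ccccc2)CC1`, gives 5800 nM.
Compound 2, `CCC(C)N(C(=O)[C@H](CC(=O)OC)NC(=O)OCc1ccccc1)C1(C(=O)NCc2ccccc2)CCN(Cc2ccccc2)CC1`, gives 5300 nM.
Compound 3, `COC(=O)C[C@H](N)C(=O)N(Cc1ccccc1)C1(C(=O)NCc2ccccc2)CCN(Cc2ccccc2)CC1`, gives 90000 nM.

Compound 3 has the highest number of the three. Its core differs from that of compound 1 by hydrogen in place of benzyloxycarbonyl on an amine nitrogen, a change that gave a 16-fold higher number from compound 1 to compound 3 (1.19 log units; beyond the scatter). Compound 1 and compound 2 differ by sec-butyl in place of benzyl on an amide-type nitrogen, which gave a 1.1-fold lower number from compound 1 to compound 2 (0.04 log units; within the scatter).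

Compound 4, `CCC(C)N(C(=O)[C@@H](N)CC(=O)OC)C1(C(=O)NCc2ccccc2)CCN(Cc2ccccc2)CC1`, has not been measured. It differs from compound 3 by sec-butyl in place of benzyl on an amide-type nitrogen, on the same kind of place, so this is the same change already seen from compound 1 to compound 2. Compound 4 is therefore expected to show a step of a 1.1-fold lower number from compound 3 to compound 4 (0.02 log units; within the scatter), resting on the earlier change, because a 1.1-fold lower number from compound 1 to compound 2 (0.04 log units; within the scatter) lay within the scatter. The estimate for compound 4 is 85000 nM, spanning 40000 nM to 180000 nM.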

Compound 4, half-maximal inhibitory concentration: 244000 nM
For compound 4 the middle estimate is 2.9-fold (0.46 log units) below the measured one; measured number outside the range, above it.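

In this assay, sec-butyl in place of benzyl on the amide-type nitrogen gave a 2.7-fold higher number from compound 3 to compound 4 (0.43 log units; beyond the scatter), so this change does not carry over at the same size to the core that lacks benzyloxycarbonyl: the same change on two cores in this assay, a 1.1-fold lower number (0.04 log units; within the scatter) from compound 1 to compound 2 and a 2.7-fold higher number (0.43 log units; beyond the scatter) from compound 3 to compound 4, 3.0-fold (0.47 log units) apart, beyond the scatter of two such steps

Hydrogen in place of benzyloxycarbonyl on the amine nitrogen gave a 46-fold higher number from compound 2 to compound 4 (1.66 log units; beyond the scatter), a step in the same direction as on the other core but not of the same size: the same change on two cores in this assay, a 16-fold higher number (1.19 log units; beyond the scatter) from compound 1 to compound 3 and a 46-fold higher number (1.66 log units; beyond the scatter) from compound 2 to compound 4, 3.0-fold (0.47 log units) apart, beyond the scatter of two such steps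

Thus the two changes do not add independently across these four compounds, though a single set of four cannot show how far this holds elsewhere in the series.

The compounds shown leave open whether the same holds for a cyclohexyl group or an ethyl chain on the amide-type nitrogen, or for an acetyl group on the amine nitrogen. They also leave open how a carboxylic acid in place of the methyl ester would behave.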